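One Side-Chain Change and Its Expected Effect

The source may report more compounds than this note shows. Statements on the series, on what has been measured and on what is new or still open speak of the compounds shown alone.

Compound 1, `O=C(CN(c1ncnc2c1ncn2C1CCCCO1)C1CC1)N[C@@H](CO)C(=O)OCc1ccccc1`, gives 32.2% in a functional assay on the whole organism (Tail, strain ICR) with Mus musculus as the target, in the tail flick test, with a stated time of 90 min, at a dose of 25 umol/kg by the oral route; a higher number here means a stronger effect of the compound at the dose given, a lower number a weaker effect.
Compound 2, `CC(C)C[C@H](NC(=O)CN(c1nc(Cl)nc2[nH]cnc12)C1CC1)C(=O)OCc1ccccc1`, gives 15.2%.

Compound 1 stands highest of the two numbers; the nearest, compound 2, lies lower by a gap beyond the usual scatter. For the measured compounds named here, no step between measured compounds exists, since compound 2 differs from compound 1 in more than one place. Compound 3, `CSCC[C@H](NC(=O)CN(c1ncnc2c1ncn2C1CCCCO1)C1CC1)C(=O)OCc1ccccc1`, differs from compound 1 by (methylsulfanyl)methyl in place of hydroxy on a saturated chain carbon, two bonds along the chain from an amide-type nitrogen and a carbonyl carbon. Going by the values given here, no measured pair shows what this change does, so the expected step, a number 2.2 percentage points lower from compound 1 to compound 3 (within the scatter) in this assay, is small: no change beyond the scatter in either direction. Compound 3 is estimated at 30%, with a range from 12% to 50%.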

Compound 3, a percentage reported as activity, at one dose (the size of the read-out at that dose, not a potency): 42.7%
Compound 3: middle estimate off by 12.7 percentage points, on the low side, within the range that was stated.
By their numbers in this assay, from the lowest: compound 2; then compound 1; then compound 3.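

In this assay, for the compounds shown here, this is the first direct reading of the saturated chain carbon, two bonds along the chain from an amide-type nitrogen and a carbonyl carbon. Putting (methylsulfanyl)methyl in place of hydroxy gives a number 10.5 percentage points higher from compound 1 to compound 3 (beyond the scatter) and removes the hydrogen-bond donor of hydroxy, so the effect here does not depend on that donor being present. Nothing measured here explains the step. Still open, on these data alone, is how an amine or a carboxylic acid at this carbon would read, and whether a longer carbon chain without sulfur would match (methylsulfanyl)methyl.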